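Phenyl for hydroxy on the side chain of compound 2

This account rests on a few compounds, and the source may have more. Where it says the series, first, only, none or still open, it means among the compounds named here.

Measured so far in a functional assay on MIA PaCa-2 cells (Homo sapiens) for inhibition, read by MTT assay, with a stated time of 72 h, tested at 30 uM; on this read-out higher numbers stand for more inhibition of growth at the one concentration tested and lower numbers for less inhibition of growth:
compound 1 `C=CCc1ccc(OCc2cn(-c3ccccc3CO)nn2)c(O)c1` gives 39.6%
compound 2 `C=CCc1cc(O)c(O)c(CN2CCC(CO)CC2)c1` gives 34.1%
compound 3 `C=CCc1ccc(OCc2cn(-c3cc(OC)c(OC)c(OC)c3)nn2)c(O)c1` gives 41.1%

Compound 2 sits within the scatter of both compound 1 and compound 3; the three numbers do not separate from one another, so no order among them can be read.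

Compound 4 `C=CCc1cc(O)c(O)c(CN2CCC(Cc3ccccc3)CC2)c1` differs from compound 2 in one place: phenyl in place of hydroxy on a saturated chain carbon bound to a saturated ring carbon. For the measured compounds named here, no pair of measured compounds differs in one place, so nothing measured here shows what size of step such a change brings. In this assay the step from compound 2 to compound 4 is expected to be a number 3.9 percentage points higher from compound 2 to compound 4 (within the scatter), which is none beyond the scatter. Compound 4 is expected to give 38%, with a range from 20% to 56%.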

Compound 4, percent growth inhibition at one concentration: 88.9%
The estimate for compound 4 lay 50.9 percentage points below the measured number, outside the stated range (above it).
By their numbers in this assay, from the lowest: compounds 2, 1 and 3 (each within the scatter of the next); then compound 4.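

In this assay, for the compounds shown here, the place on a saturated chain carbon bound to a saturated ring carbon proves strongly responsive: hydroxymethyl to benzyl gives a number 54.8 percentage points higher from compound 2 to compound 4 (beyond the scatter) as the first step that can be read at all. Going by these compounds alone, nothing among the earlier compounds gave any sign of a change of this size. No measurement at hand bears on why the step arises. Still open, as far as these compounds go, is whether the gain follows the added phenyl or the lost hydroxy; a methyl, an aminomethyl or a longer chain such as phenethyl at this place would separate the two.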